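The source may hold more compounds than are shown below. What is called first, only, known or untested is meant among the compounds shown, and "the series" means these compounds.

Compound 1, `Oc1ccc(O)c(COCc2cc(O)cc(Cl)c2O)c1`, gives 18300 nM in a functional assay on A549 cells (Homo sapiens) for cytotoxicity, read by sulforhodamine B assay; a higher number here means a weaker inhibitor, a lower number a stronger inhibitor. Compound 2, `Oc1ccc(O)c(COCc2cc(O)ccc2O)c1`, gives 18200 nM in this assay. Compound 3, `COCc1cc(O)cc(Cl)c1O`, gives 56500 nM in this assay.

The pair of compounds 1 and 2 shows one change: hydrogen in place of chloro on an aromatic carbon. Its effect is a 1.0-fold lower number from compound 1 to compound 2 (0.00 log units; within the scatter). Compound 3 stands apart from both, with a higher number than compound 1 and than compound 2, and the difference between its core and the core of compound 1 is not broken down here.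

Compound 4, `COCc1cc(O)ccc1O`, has not yet been measured in this assay. It differs from compound 3 by the same kind of change: hydrogen in place of chloro on an aromatic carbon. The surroundings are not word for word the same as in the first pair: in compound 1 the position was meta to a large group, while in compound 3 it is meta to a methoxymethyl group (3 heavy atoms); otherwise the place is alike, ortho to a hydroxy group and meta to a hydroxy group.

Because a 1.0-fold lower number from compound 1 to compound 2 (0.00 log units; within the scatter) lay within the scatter, the corresponding step for compound 4 is expected to be small as well, so that compound 4 would stay close to compound 3, with the expected step being a 1.0-fold lower number from compound 3 to compound 4 (0.01 log units; within the scatter). On that basis, compound 4 is estimated at 55000 nM in this assay, with a likely range from 25000 nM to 120000 nM.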

Compound 4, half-maximal inhibitory concentration: > 100000 nM
Compound 4: only a limit was reported; the forecaster's own chance of this, stated with the estimate: 20%; at least 1.8-fold (0.25 log units) between middle value and limit.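

In this assay compound 4 gives > 100000 nM, which is a limit of the assay and not a number. Hydrogen in place of chloro gives an at least 1.7-fold higher number from compound 3 to compound 4 (0.24 log units; that floor lies within the scatter), and set beside the earlier result on the core of compound 1, this allows only a limited comparison: the same change on two cores in this assay, a 1.0-fold lower number (0.00 log units; within the scatter) from compound 1 to compound 2 and an at least 1.7-fold higher number (0.24 log units; that floor lies within the scatter) from compound 3 to compound 4; the limit leaves it open whether they differ The data therefore neither show that the negligible step seen on the core of compound 1 carries over to the core of compound 3 nor show that it fails to carry over, and the true size of the step on the core of compound 3 remains unknown, with the reading cut off at the assay's limit: the limit of > 100000 nM in this assay, at which 1 of the 4 values shown sits.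

The compounds shown leave open how a fluoro, bromo or methyl group in place of chloro at this same place, ortho to a hydroxy group and meta to a hydroxy group, would read on either core. They also leave open whether the same change would give a step of similar size if an amine or a longer chain stood in place of the methoxymethyl group.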